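The source may hold more compounds than are shown below. What is called first, only, known or untested is meant among the compounds shown, and "the series" means these compounds.

Compound 1 `CCOCC1CN(c2ccccc2)NC1=O` gives 280 nM
Compound 2 `CCCOCC1CN(c2ccccc2)NC1=O` gives 260 nM
Compound 3 `O=C1NN(c2ccccc2)CC1Cc1cccs1` gives 140 nM

All three were run in an assay on isolated protein for inhibition of Polyunsaturated fatty acid 5-lipoxygenase (Rattus norvegicus); on this read-out lower numbers stand for stronger inhibition and higher numbers for weaker inhibition. Compound 3 holds the lowest of the three numbers, but both other compounds sit close to it: a 2.0-fold lower number from compound 1 to compound 3 (0.30 log units; within the scatter) and a 1.9-fold lower number from compound 2 to compound 3 (0.27 log units; within the scatter), each within the scatter, so compound 3 cannot be set apart from compound 1 or compound 2. The remaining measured step, a 1.1-fold lower number from compound 1 to compound 2 (0.03 log units; within the scatter), also lies within the scatter.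

Compound 4 `CCSC1CN(c2ccccc2)NC1=O` is not yet measured. Relative to compound 3 the change is ethylsulfanyl in place of (thiophen-2-yl)methyl on a saturated ring carbon. The measured steps that bear on it are the two at the same ring carbon, a 2.0-fold lower number from compound 1 to compound 3 (0.30 log units; within the scatter) and a 1.9-fold lower number from compound 2 to compound 3 (0.27 log units; within the scatter), where exchanging the ethoxy or propoxy chain for the thiophene-bearing chain moved the number very little. For the measured compounds named here, the group entering in compound 4 is the smallest placed at that position so far, and no measured step covers a group of that kind, so the expectation rests on the weak response of the series to substitution there. The step expected in this assay is a 1.9-fold higher number from compound 3 to compound 4 (0.27 log units; within the scatter), a small drift toward a higher number rather than anything beyond the scatter. Compound 4 is therefore estimated at 260 nM, with a range of 110 nM to 650 nM.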

Compound 4, half-maximal inhibitory concentration: 60 nM
Compound 4: the middle estimate sits 4.3-fold (0.64 log units) above what was measured; the measured number lies below the stated range.
By their numbers in this assay, from the lowest: compound 4; then compounds 3, 2 and 1 (each within the scatter of the next).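

In this assay, for the compounds shown here, the saturated ring carbon, two ring bonds from the ring nitrogen, now shows a response to substitution that the earlier compounds, all within the scatter of their nearest neighbours, did not reveal. Ethylsulfanyl, with 3 heavy atoms and no ring, gives a step beyond the scatter against each group it replaces: (thiophen-2-yl)methyl (a 2.3-fold lower number from compound 3 to compound 4 (0.37 log units; beyond the scatter)), propoxymethyl (a 4.3-fold lower number from compound 2 to compound 4 (0.64 log units; beyond the scatter)) and ethoxymethyl (a 4.7-fold lower number from compound 1 to compound 4 (0.67 log units; beyond the scatter)), so the group with the fewest heavy atoms here also gives the lowest number, though only four compounds support this. Nothing at hand accounts for this difference.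

Each of these steps changes the entering atom and the attachment together, since the three earlier groups reach the ring through a saturated chain carbon and ethylsulfanyl does not, so the compounds shown cannot separate the contribution of the sulfur from that of the shorter attachment. Ethoxy directly on that ring carbon, ethylsulfanylmethyl, and methylsulfanyl or a longer alkylsulfanyl chain would address these questions, and an amine at the same carbon remains an open comparison.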